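Replacing the ester on the piperidine ring with an amine

The source may report more compounds than this note shows. Statements on the series, on what has been measured and on what is new or still open speak of the compounds shown alone.

Two compounds share a core in which a saturated six-membered ring bearing one nitrogen carries a variable group on a ring carbon. Compound 1 `COC1CCN(c2nc(C(F)(F)F)ccc2CNC(=O)C(C)c2ccc(NS(C)(=O)=O)c(F)c2)CC1` has a methyl on an oxygen at that position, and in a functional assay on CHO-K1 cells for antagonist activity at transient receptor potential cation channel subfamily V member 1 (Homo sapiens), read by FLIPR (on this read-out higher numbers stand for weaker inhibition and lower numbers for stronger inhibition), compound 1 gives 280 nM. Compound 2 `CC(C(=O)NCc1ccc(C(F)(F)F)nc1N1CCC(OC(=O)C(C)(C)C)CC1)c1ccc(NS(C)(=O)=O)c(F)c1` carries a (tert-butyl)carbonyl on that oxygen instead, and in this assay compound 2 gives 45.2 nM. Among the compounds with values here, that change produced a 6.2-fold lower number from compound 1 to compound 2 (0.79 log units; beyond the scatter), so compound 2 stands as the stronger of the two measured compounds, with compound 1 the only neighbour. Compound 3 `CC(C(=O)NCc1ccc(C(F)(F)F)nc1N1CCC(CN(C)C)CC1)c1ccc(NS(C)(=O)=O)c(F)c1` introduces a different kind of group at the same place: (dimethylamino)methyl in place of ((tert-butyl)carbonyl)oxy on a saturated ring carbon. Within the data shown here, the single measured step shows that this position tolerates a sizeable change and that the group there can shift the number by a modest amount, but nothing measured so far involves a basic amine, so the direction is uncertain. The expectation for compound 3 is a moderate loss relative to compound 2, giving a 3.3-fold higher number from compound 2 to compound 3 (0.52 log units; beyond the scatter), with an estimated value of 150 nM and a range from 40 nM to 600 nM.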

Compound 3, half-maximal inhibitory concentration: 426 nM
For compound 3 the middle estimate is 2.8-fold (0.45 log units) below the measured one, and the stated range covers the measured number.
By their numbers in this assay, from the lowest: compound 2; then compounds 1 and 3 (each within the scatter of the next).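

In this assay, putting (dimethylamino)methyl in place of ((tert-butyl)carbonyl)oxy on the saturated ring carbon gives a 9.4-fold higher number from compound 2 to compound 3 (0.97 log units; beyond the scatter), so the stronger inhibition seen with compound 2 does not carry over to this amine-bearing group. Putting (dimethylamino)methyl in place of methoxy at the same ring carbon gives a 1.5-fold higher number from compound 1 to compound 3 (0.18 log units; within the scatter), so the numbers for these two groups cannot be told apart in this read-out, even though the groups differ in kind. The position therefore now has two groups that sit within the scatter of each other and one, ((tert-butyl)carbonyl)oxy, that stands clear of both.

Nothing available on these compounds accounts for why the ((tert-butyl)carbonyl)oxy group stands apart from the other two. From the compounds shown here alone, it remains open whether that gap belongs to the carbonyl, to the tert-butyl part or to the overall size of the group, and how an amide, a carboxylic acid or a longer chain ending in a dimethylamino group would read on that ring carbon.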